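The compounds below may be only part of what the source reports. "The series", "measured", "known", "first", "only" and "open" are said of these compounds alone.

Measured compounds:
compound 1 `CCCCCCNc1[nH]ccc2ncnc1-2`: 100%
compound 2 `CN(C)c1[nH]ccc2ncnc1-2`: 25%
compound 3 `Nc1[nH]ccc2ncnc1-2`: < 5%

In a functional assay on EL4 cells (Mus musculus) for inhibition, tested at 100 uM (a higher number here means more inhibition at the concentration tested (going by the name of the read-out), a lower number less inhibition), compound 1 gives 100% and compound 2 gives 25%. For compound 3 only a limit of the assay is known, < 5%, so it sits at the bottom of the numbers shown, because of the limit of < 5% in this assay, at which 1 of the 3 values shown sits. For the measured compounds named here, the step of a number at least 20 percentage points lower from compound 2 to compound 3 (beyond the scatter) is the one change measured so far, and it came with the loss of two methyl groups from the nitrogen.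

Compound 4 `CCNc1[nH]ccc2ncnc1-2` is not yet measured. It differs from compound 3 by ethyl in place of hydrogen on a nitrogen on an aromatic ring. The step from compound 2 to compound 3 bears on this change directly, since putting carbon back onto that nitrogen reverses its direction; the values of compound 1 and compound 3 point the same way, though no single step between them is shown. A rise beyond the scatter in this assay is therefore expected, of the size a number at least 30 percentage points higher from compound 3 to compound 4 (beyond the scatter). Compound 4 is expected to give 35%, within 10% to 70%.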

Compound 4, a percentage reported as inhibition, at one concentration (the size of the read-out at that concentration, not a potency): < 5%
Compound 4 was reported as a limit; the forecaster's own chance of this, stated with the estimate: 15%; middle value at least 30 percentage points from the limit.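

Carbon on this nitrogen does not bring inhibition by itself: ethylamino in place of dimethylamino gives a number at least 20 percentage points lower from compound 2 to compound 4 (beyond the scatter), so these two groups are not interchangeable here. Replacing the butyl end of the longer chain with hydrogen gives a number at least 95 percentage points lower from compound 1 to compound 4 (beyond the scatter), which shows that in this assay chain length on this nitrogen matters, at least for this pair. Whether ethyl changes anything compared with hydrogen cannot be read, since compound 3 and compound 4 both rest on the same assay limit: the limit of < 5% in this assay, at which 2 of the 4 values shown sit.

Still open is where inhibition begins between the ethyl chain and the longest chain shown, which a propyl or butyl chain on the same nitrogen would help to place. Also open, as far as these compounds go, is whether diethylamino would match or exceed dimethylamino.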